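The source may report more compounds than this note shows. Statements on the series, on what has been measured and on what is new or still open speak of the compounds shown alone.

Compound 3 `O=C1CCCN1c1cnc(NCc2c(F)ccc3c2CCO3)n2cnnc12` stands at the floor of an ADME assay on microsomes from liver (Homo sapiens) for metabolic stability, read by LC-MS, using NADPH, with stated times of 5 min and 30 min, tested at 1 uM; on this read-out higher numbers stand for fast clearance and lower numbers for slow clearance: its reading < 3 mL.min-1.g-1 is a limit of the assay rather than a number (the limit of < 3 mL.min-1.g-1 in this assay, at which 1 of the 3 values shown sits). In the related series, compound 1 `CN(c1ccn(C)n1)c1cnc(NCc2c(F)ccc3c2CCO3)c2cn[nH]c(=O)c12` gives 62 mL.min-1.g-1 in this assay, and compound 2 `Cn1cc(-c2cnc(NCc3c(F)ccc4c3CCO4)c3cn[nH]c(=O)c23)cn1` gives 21 mL.min-1.g-1; the one measured step, a 3.0-fold lower number from compound 1 to compound 2 (0.47 log units; beyond the scatter), changes the same position but involves neither group at issue here. Compound 4 `CN(c1ncco1)c1cnc(NCc2c(F)ccc3c2CCO3)n2cnnc12` carries methyl(1,3-oxazol-2-yl)amino in place of 2-oxopyrrolidin-1-yl on an aromatic carbon. Among the compounds with values here, no measured step bears directly on this exchange; the nearest guide is compound 1, whose methyl(heteroaryl)amino substituent gave 62 mL.min-1.g-1. The change is therefore expected to raise the number, an at least 4.0-fold higher number from compound 3 to compound 4 (0.60 log units; beyond the scatter), with wide uncertainty. Compound 4 is estimated at 12 mL.min-1.g-1, between 3 mL.min-1.g-1 and 45 mL.min-1.g-1.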

Compound 4, intrinsic clearance in microsomes: 11 mL.min-1.g-1
For compound 4 the middle estimate is 1.1-fold (0.04 log units) above the measured one; low and high end bracket the measured number.
By their numbers in this assay, from the lowest: compounds 4 and 2 (each within the scatter of the next); then compound 1. At a limit, below all of these: compound 3.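

Methyl(1,3-oxazol-2-yl)amino in place of 2-oxopyrrolidin-1-yl on this aromatic carbon gives an at least 3.6-fold higher number from compound 3 to compound 4 (0.56 log units; beyond the scatter) in this assay, so clearance responds to the group at this position on this core. The size of that step stays a lower bound, as compound 3 reads only as a limit of the assay: the limit of < 3 mL.min-1.g-1 in this assay, at which 1 of the 4 values shown sits.

Open, going by these compounds, is whether the rise follows the oxazole ring or the methylated amine nitrogen linking it to the core. A dimethylamino group or a morpholine on the same carbon would separate the two.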